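The source may hold more compounds than are shown below. What is called first, only, known or untested is meant among the compounds shown, and "the series" means these compounds.

Measured compounds:
Compound 1, `COc1cc(-c2nnc3n2NC(c2ccco2)C(C(=O)c2cccs2)S3)cc(OC)c1OC`, gives 78700 nM.
Compound 2, `COc1cc(-c2nnc3n2NC(c2ccco2)C(C(=O)c2ccc(F)cc2)S3)cc(OC)c1OC`, gives 53700 nM.

These two compounds were tested in a functional assay on A549 cells (Homo sapiens) for cytotoxicity, read by MTT assay, with a stated time of 48 h; on this read-out higher numbers stand for weaker inhibition and lower numbers for stronger inhibition. For the measured compounds named here, on the numbers at hand compound 2 stands at the lowest value, with compound 1 nearest to it; the single measured step, a 1.5-fold lower number from compound 1 to compound 2 (0.17 log units; within the scatter), exchanged one aromatic group for another on the carbonyl carbon and stayed within the scatter.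

Compound 3, `COc1cc(-c2nnc3n2NC(c2ccco2)C(C(=O)c2ccc(C)cc2)S3)cc(OC)c1OC`, differs from compound 2 by methyl in place of fluoro on an aromatic carbon. Going by the values given here, the only measured step that bears on this change is the earlier swap on the same part of the molecule, a 1.5-fold lower number from compound 1 to compound 2 (0.17 log units; within the scatter), which was small. Nothing here points to a change larger than the scatter, so for compound 3 the expected step is a 1.1-fold lower number from compound 2 to compound 3 (0.03 log units; within the scatter). The estimate for compound 3 is therefore 50000 nM, within a range of 20000 nM to 120000 nM.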

Compound 3, half-maximal inhibitory concentration: > 100000 nM
Compound 3: no number, only a limit (the forecaster's own chance of this, stated with the estimate: 10%); at least 2.0-fold (0.30 log units) between middle value and limit.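

In this assay the reading for compound 3 is a limit and not a number: the limit of > 100000 nM in this assay, at which 1 of the 3 values shown sits. Methyl in place of fluoro on this aromatic carbon gives an at least 1.8-fold higher number from compound 2 to compound 3 (0.27 log units; that floor lies within the scatter) and 4-methylphenyl in place of thiophen-2-yl gives an at least 1.2-fold higher number from compound 1 to compound 3 (0.10 log units; that floor lies within the scatter); both are floors, and each floor lies within the scatter. For the compounds shown here, the earlier compounds had given this part of the molecule only a single step within the scatter, whereas this change gives a step with a floor but no upper bound, so it may be larger than that floor or no larger.

From the compounds shown here alone, the true size of both steps therefore stays open. Also open, going by these compounds, is whether an amine or a carboxylic acid on the same aromatic carbon would give a number rather than a limit, and on which side of compound 2 that number would fall.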